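Turning the Single Stereocentre of Compound 1 Around

This account rests on a few compounds, and the source may have more. Where it says the series, first, only, none or still open, it means among the compounds named here.

Compound 1 `COc1ccccc1OCCNC[C@@H](O)COc1c(OC)ccc2[nH]ccc12` gives 45.8 nM in an assay on membranes from Cerebral cortex (strain Wistar) for displacement of a labelled ligand from Adrenergic receptor alpha-1 (Rattus norvegicus), read by scintillation counting; on this read-out lower numbers stand for stronger inhibition and higher numbers for weaker inhibition. Compound 2 `COc1ccccc1OCCNC[C@@H](O)COc1ccc(OC)c2[nH]ccc12` gives 60.9 nM in this assay, a gap that lies within the scatter, so compound 1 simply holds the lower of two close numbers. Compound 3 `COc1ccccc1OCCNC[C@H](O)COc1c(OC)ccc2[nH]ccc12` differs from compound 1 in one respect: the two compounds have the same atoms and bonds and differ only in configuration as drawn: 1 of 1 stereo elements differ; a stereocentre at a saturated chain carbon is drawn R in compound 1 and S in compound 3. Going by the values given here, no measured pair shows what this change does here, so the expectation rests on compound 1 alone. A step toward a higher number is expected, from compound 1 to compound 3 a 1.7-fold higher number from compound 1 to compound 3 (0.24 log units; within the scatter), though it may not exceed the scatter. Compound 3 is estimated at 80 nM, within a range from 25 nM to 300 nM.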

Compound 3, inhibition constant: 11.3 nM
For compound 3 the middle estimate is 7.1-fold (0.85 log units) above the measured one; measured number below the stated range.
By their numbers in this assay, from the lowest: compound 3; then compounds 1 and 2 (each within the scatter of the next).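

In this assay, the configuration at this saturated chain carbon clearly matters: turning the stereocentre from R to S gives a 4.1-fold lower number from compound 1 to compound 3 (0.61 log units; beyond the scatter). The earlier compounds shown here could not show this, as both are drawn with the same configuration at this carbon and their numbers lie within the scatter. The step can be assigned to this stereocentre alone because nothing else changes: the fact that compounds 1 and 3 differ only in the configuration as drawn

Going by these compounds, whether the same turn would shift the number for compound 2 in the same direction remains open. So does whether an amine in place of the hydroxyl on this carbon would keep the preference for S.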